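Chloro substitution on two isatin-oxime hydroxamate cores

This account rests on a few compounds, and the source may have more. Where it says the series, first, only, none or still open, it means among the compounds named here.

Measured in a functional assay on MCF7 cells (Homo sapiens) for antiproliferative activity, read by sulforhodamine B assay, with a stated time of 48 h; on this read-out higher numbers stand for weaker inhibition and lower numbers for stronger inhibition:
compound 1, `O=C(CCCCCCN1C(=O)/C(=N\O)c2ccccc21)NO`, gives 790 nM
compound 2, `O=C(CCCCCCN1C(=O)/C(=N\O)c2cc(Cl)ccc21)NO`, gives 680 nM
compound 3, `CO/N=C1/C(=O)N(CCCCCCC(=O)NO)c2ccccc21`, gives 1710 nM

Compounds 1 and 2 share one core, compound 3 carries another; the difference between the two cores is not broken down here. Compound 3 stands at the highest of the three numbers, and its gap to compound 1 is beyond the scatter.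

The step from compound 1 to compound 2 is chloro in place of hydrogen on an aromatic carbon, and in this assay it made a 1.2-fold lower number from compound 1 to compound 2 (0.07 log units; within the scatter). Compound 4, `CO/N=C1/C(=O)N(CCCCCCC(=O)NO)c2c(Cl)cccc21`, is yet to be measured; relative to compound 3 the change is chloro in place of hydrogen on an aromatic carbon. The same kind of change, though the place differs: meta to a fused ring and para to a fused ring in compound 2, ortho to a fused ring and meta to a fused ring in compound 4. Given compound 3 at 1710 nM and the small step seen from compound 1 to compound 2, compound 4 is expected to show a 1.1-fold lower number from compound 3 to compound 4 (0.06 log units; within the scatter). The estimate for compound 4 in this assay is 1500 nM.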

Compound 4, half-maximal inhibitory concentration: 340 nM
Compound 4: the middle estimate sits 4.4-fold (0.64 log units) above what was measured; measured number outside the range, below it.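

In this assay, chloro in place of hydrogen on an aromatic carbon gives a 5.0-fold lower number from compound 3 to compound 4 (0.70 log units; beyond the scatter), and the size of this change does not carry unchanged from one core to the other: the same change on two cores in this assay, a 1.2-fold lower number (0.07 log units; within the scatter) from compound 1 to compound 2 and a 5.0-fold lower number (0.70 log units; beyond the scatter) from compound 3 to compound 4, 4.3-fold (0.64 log units) apart, beyond the scatter of two such steps

The two steps differ in the core and also in where the chloro sits, so this pair does not show which of the two accounts for the gap. Two steps also set no rule for the series.

Open, going by these compounds, is what chloro gives on the core of compound 1 at the place it holds in compound 4, and on the core of compound 3 at the place it holds in compound 2. Also open, on these data alone, is whether fluoro or bromo at the place held in compound 4 would give a step of similar size.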